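This account rests on a few compounds, and the source may have more. Where it says the series, first, only, none or still open, it means among the compounds named here.

Measured compounds and their values:

compound 1, `FC(F)(F)c1cccc(NC(=S)Nc2cccc(Br)c2)c1`: 10000 nM
compound 2, `CCCCc1ccc(NC(=S)Nc2cccc(C(F)(F)F)c2)c(C)c1`: 10000 nM
compound 3, `Cc1ccc(NC(=S)Nc2cccc(C(F)(F)F)c2)cc1Cl`: 10000 nM

These three compounds share the same core and differ only in the groups attached to its two outer rings. In an ADME assay on MDBK cells (Bos taurus) for cytotoxicity, read by MTT assay, with a stated time of 96 h (on this read-out lower numbers stand for higher toxicity in this test and higher numbers for lower toxicity in this test), compound 1 gives 10000 nM. Compound 2 gives 10000 nM and compound 3 gives 10000 nM, so compound 1 stands level with both at the digits shown; its nearest neighbour is compound 2 and its furthest is compound 3, and neither gap goes beyond the usual scatter of repeated measurements.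

Compound 4, `Fc1cccc(NC(=S)Nc2cccc(C(F)(F)F)c2)c1`, has not yet been tested in this assay. It differs from compound 1 in one place: fluoro in place of bromo on an aromatic carbon.

Among the compounds with values here, no pair of measured compounds that differ in a single place is available, so no measured step can guide the expectation. What the three values do show is that differing groups on the outer rings left the read-out unchanged. On that basis the step from compound 1 to compound 4 is expected to be none beyond the scatter, no change at the digits printed from compound 1 to compound 4 (within the scatter). Compound 4 is therefore estimated at 10000 nM, with a range from 5000 nM to 20000 nM.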

Compound 4, half-maximal cytotoxic concentration: 10000 nM
Beside the measured number, compound 4's estimate shows no gap at the digits printed; low and high end bracket the measured number.
By their numbers in this assay, from the lowest: compounds 1, 2, 3 and 4 (each within the scatter of the next).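

Within the data shown here, this pair is the first in the set to differ in one place only, so it gives a direct reading: in this assay, putting fluoro in place of bromo on an aromatic carbon, meta to a large group, gives no change at the digits printed from compound 1 to compound 4 (within the scatter). Among these compounds, at this position, then, this read-out does not tell the two halogens apart, something the earlier compounds could not show, as no two of them differed in a single place. Nothing at hand accounts for this result.

On these data alone, it remains open whether a group of another kind at this position, such as an amine, a carboxylic acid or a longer chain, would shift the value in this assay. As far as these compounds go, it also remains open whether fluoro or bromo would give the same reading elsewhere on the ring.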